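Cyano for Trifluoromethyl on a Weakly Active Scaffold

The compounds below may be only part of what the source reports. "The series", "measured", "known", "first", "only" and "open" are said of these compounds alone.

Compound 1, `CC1=C(C(=O)OC2CCCCC2)C(c2ccc3c(c2)OCCO3)C2=C(CC(C)(C)CC2=O)N1`: 12300 nM
Compound 2, `CC1=C(C(=O)OC2CCCCC2)C(c2cccc(C(F)(F)F)c2)C2=C(CC(C)(C)CC2=O)N1`: 14700 nM

In an assay on HEK293 cells for inhibition of neurogenic locus notch homolog protein 1 (Homo sapiens), read by a luciferase reporter and resazurin assay, with a stated time of 16 h (on this read-out lower numbers stand for stronger inhibition and higher numbers for weaker inhibition), compound 2 gives 14700 nM. Of the two numbers shown, this one cannot be separated from that of compound 1, because a 1.2-fold higher number from compound 1 to compound 2 (0.08 log units; within the scatter). Compound 3, `CC1=C(C(=O)OC2CCCCC2)C(c2cccc(C#N)c2)C2=C(CC(C)(C)CC2=O)N1`, differs from compound 2 by cyano in place of trifluoromethyl on an aromatic carbon. Within the data shown here, no measured step touches this particular change; the only step available, exchanging the whole aryl group, stayed within the scatter. A step of a 1.1-fold lower number from compound 2 to compound 3 (0.05 log units; within the scatter) is therefore expected, meaning no shift beyond the scatter. Compound 3 is expected to give about 13000 nM in this assay, with a plausible range from 5000 nM to 35000 nM.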

Compound 3, half-maximal inhibitory concentration: 43200 nM
Estimate against measurement, compound 3: 3.3-fold (0.52 log units) below, and the stated range ends below it.
By their numbers in this assay, from the lowest: compounds 1 and 2 (each within the scatter of the next); then compound 3.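

In this assay the group on this aromatic carbon does matter: cyano in place of trifluoromethyl gives a 2.9-fold higher number from compound 2 to compound 3 (0.47 log units; beyond the scatter) and so weaker inhibition, whereas the earlier aryl exchange stayed within the scatter. An aryl exchange can therefore also register, as 3-cyanophenyl in place of 2,3-dihydro-1,4-benzodioxin-6-yl gives a 3.5-fold higher number from compound 1 to compound 3 (0.55 log units; beyond the scatter) on the same core. Nothing available explains why cyano weakens inhibition here. As far as these compounds go, whether an amine, a carboxylic acid or a methoxy group on this carbon would give a lower number remains open.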